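Swapping a dichlorophenyl for a methylthiophene in a growth-inhibition series

The source may report more compounds than this note shows. Statements on the series, on what has been measured and on what is new or still open speak of the compounds shown alone.

Measured in a functional assay on DU-145 cells (Homo sapiens) for inhibition, read by trypan blue exclusion, with a stated time of 96 h; a lower number here means a stronger inhibitor of growth, a higher number a weaker inhibitor of growth:
- compound 1 `Cc1ccsc1/C=C(/SCc1ccc(Cl)cc1)C(=O)c1ccc(Cl)cc1`: 50000 nM
- compound 2 `COc1ccc(/C=C(/SCc2ccc(Cl)cc2)C(=O)c2ccc(Br)cc2)cc1O`: 1000 nM
- compound 3 `O=C(/C(=C\c1cccc(Cl)c1Cl)SCc1ccc(Cl)cc1)c1ccc(Br)cc1`: 10000 nM

Compound 3 holds the middle place of these three numbers, with a higher number than compound 2 and a lower number than compound 1. The next compound, compound 4 `Cc1ccsc1/C=C(/SCc1ccc(Cl)cc1)C(=O)c1ccc(Br)cc1`, keeps the rest of compound 3 and changes one group: 3-methylthiophen-2-yl in place of 2,3-dichlorophenyl on a double-bonded chain carbon bound to a double-bonded chain carbon. In short, 3-methylthiophen-2-yl takes the place of 2,3-dichlorophenyl.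

Within the data shown here, one measured step touches the same place. It is a 10-fold higher number from compound 2 to compound 3 (1.00 log units; beyond the scatter), with 2,3-dichlorophenyl replacing 3-hydroxy-4-methoxyphenyl. So a change here has already moved the number well beyond the scatter, although that step involves a different group.

The closest guide is compound 1, which already carries 3-methylthiophen-2-yl and gives 50000 nM. Among the measured compounds shown here, it differs from compound 4 elsewhere in the molecule, and no measured pair shows what that difference does. A move to a higher number, and so a weaker inhibitor of growth, therefore seems likely in this assay, probably stopping short of the value of compound 1. The expected change is a 2.5-fold higher number from compound 3 to compound 4 (0.40 log units; beyond the scatter). For compound 4 the estimated value is 25000 nM, with an expected range of 8000 nM to 60000 nM.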

Compound 4, concentration for 50% growth inhibition: 25000 nM
Estimate against measurement, compound 4: no gap at the digits printed; measured number inside the range.
By their numbers in this assay, from the lowest: compound 2; then compound 3; then compounds 4 and 1 (each within the scatter of the next).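

In this assay the swap of 2,3-dichlorophenyl for 3-methylthiophen-2-yl gives a 2.5-fold higher number from compound 3 to compound 4 (0.40 log units; beyond the scatter), so a second change at this position, now between two groups that both lack a hydroxy group, also moves the number beyond the scatter. Measured against 3-hydroxy-4-methoxyphenyl, the same thiophene group gives a 25-fold higher number from compound 2 to compound 4 (1.40 log units; beyond the scatter), and with the rest of the molecule held constant the three groups now form a clear order at this position, with 3-hydroxy-4-methoxyphenyl giving the lowest number and 3-methylthiophen-2-yl the highest. Among these compounds, the result also offers the first direct look at the halogen on the other ring: bromo in place of chloro gives a 2.0-fold lower number from compound 1 to compound 4 (0.30 log units; within the scatter), so this pair cannot be told apart in this assay.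

Nothing available here explains why these groups differ in growth inhibition. Going by these compounds, it also remains open whether the low number of compound 2 depends on its hydroxy group, its methoxy group or both, and how a group such as an amine or a carboxylic acid would behave at this position.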